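This account rests on a few compounds, and the source may have more. Where it says the series, first, only, none or still open, it means among the compounds named here.

Measured compounds:
- Compound 1, `CN1C(=O)C(c2ccc(F)cc2)N(C)c2nc(Nc3ccc(S(N)(=O)=O)cc3)ncc21`, in an assay on Sf9 cells for inhibition of serine/threonine-protein kinase 4 (Homo sapiens), read by luminescence and ADP-Glo, with a stated time of 1 h, in the presence of a further agent that is not named here (a lower number here means a stronger inhibitor, a higher number a weaker inhibitor), compound 1 gives 1770 nM.
- Compound 2, `CN1C(=O)C(c2cccc(C(F)(F)F)c2)N(C)c2nc(Nc3ccc(S(N)(=O)=O)cc3)ncc21`, in this assay compound 2 gives 2710 nM.

Among the compounds with values here, compound 2 holds the higher of the two numbers, but the only step that reaches it, a 1.5-fold higher number from compound 1 to compound 2 (0.18 log units; within the scatter), lies within the scatter, so the two values are not distinguished. Compound 3, `COc1ccccc1C1C(=O)N(C)c2cnc(Nc3ccc(S(N)(=O)=O)cc3)nc2N1C`, is not yet measured; it differs from compound 2 as follows: 2-methoxyphenyl in place of 3-(trifluoromethyl)phenyl on a saturated ring carbon. Within the data shown here, the one measured step bears on this change only loosely: it shows that exchanging the aryl group on the saturated ring carbon, from 4-fluorophenyl to 3-(trifluoromethyl)phenyl, left the number within the scatter. Among the measured compounds shown here, no step with a 2-methoxyphenyl group exists. Compound 3 is therefore expected to stay near compound 2, with a 1.1-fold lower number from compound 2 to compound 3 (0.04 log units; within the scatter) as the anticipated step, and the estimate for compound 3 is 2500 nM, expected to fall between 900 nM and 7000 nM.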

Compound 3, half-maximal inhibitory concentration: 251 nM
Compound 3: the middle estimate sits 10-fold (1.00 log units) above what was measured; the measured number lies below the stated range.
By their numbers in this assay, from the lowest: compound 3; then compounds 1 and 2 (each within the scatter of the next).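

At this position the aryl group is not interchangeable, although the earlier exchange stayed within the scatter: in this assay the change to 2-methoxyphenyl gives an 11-fold lower number from compound 2 to compound 3 (1.03 log units; beyond the scatter) and, measured against the 4-fluorophenyl compound, a 7.1-fold lower number from compound 1 to compound 3 (0.85 log units; beyond the scatter) as well. Both steps lie beyond the scatter, so compound 3 stands apart from the other two compounds, which remain undistinguished from each other. No measurement shown accounts for this drop in the number.

The compounds shown do not separate the effect of the methoxy group itself from that of its place on the phenyl ring, as each aryl group differs in both respects. As far as these compounds go, it also remains open whether a hydroxyl group, an amine or a longer ethoxy chain in place of the methoxy group would keep the lower number.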